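This account rests on a few compounds, and the source may have more. Where it says the series, first, only, none or still open, it means among the compounds named here.

Measured so far:
compound 1, `CCCNc1ccc(C(=O)N2CCCCc3ccccc32)c(Cl)c1` — 18 nM
compound 2, `O=C(c1ccc(-n2cccc2)cc1)N1CCCCc2ccccc21` — 320 nM

Two compounds on the shared core carry numbers in an assay on HeLa cells for binding affinity to Vasopressin V2 receptor (Homo sapiens); a lower number here means a stronger inhibitor, a higher number a weaker inhibitor. Compound 1 gives 18 nM, the lower of the two; compound 2 gives 320 nM, a higher number, and the gap between them lies beyond the scatter of this assay. Compound 1 therefore stands at the low end of what has been seen, with no measured neighbour close to it. For the measured compounds named here, no pair of measured compounds differs in a single place, so no step in this assay is known as yet.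

Compound 3, `O=C(c1ccc(N2CCCC2)cc1Cl)N1CCCCc2ccccc21`, follows from compound 1 by a single change: pyrrolidin-1-yl in place of propylamino on an aromatic carbon. The new group closes the open chain of compound 1 into a ring and gives up the hydrogen-bond donor, while the chloro group and the rest of the core stay as in compound 1. Nothing measured tells how such a change plays out on this core, so the expectation leans on compound 1 alone and is worded as an estimate. The step from compound 1 to compound 3 is expected to be small, a 1.2-fold lower number from compound 1 to compound 3 (0.08 log units; within the scatter), not clearly beyond the scatter in either direction. For compound 3 the estimated value in this assay is 15 nM, with a range from 4 nM to 60 nM.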

Compound 3, half-maximal inhibitory concentration: 9 nM
Compound 3: middle estimate off by 1.7-fold (0.22 log units), on the high side, within the range that was stated.
By their numbers in this assay, from the lowest: compounds 3 and 1 (each within the scatter of the next); then compound 2.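

In this assay, pyrrolidin-1-yl in place of propylamino on this aromatic carbon, meta to a chloro group and para to a large group, gives a 2.0-fold lower number from compound 1 to compound 3 (0.30 log units; within the scatter). At this position the open chain can therefore be closed into a five-membered non-aromatic ring, with the hydrogen-bond donor of propylamino gone, and the number stays within the scatter of that of compound 1. A hydrogen-bond donor on this carbon is thus not required for a low number on this core, although no reason for the result can be drawn from the available data.

Still open, on these data alone, is how far this tolerance extends on the same carbon: whether a piperidin-1-yl or morpholin-4-yl ring, a dimethylamino group or a longer chain such as butylamino would also stay within the scatter of compound 1 and compound 3. Also open, as far as these compounds go, is what the chloro group contributes, since a version of compound 3 with hydrogen or fluoro in its place would be needed to read that change alone, and compound 2 differs from compound 3 in more than one place.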